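Swapping one halogen for another on a cytotoxicity series

A few compounds are considered here, and "the series" means these few. Any claim that something is new, unique, unknown or untested is made for them only; others in the source may bear on it.

Of the compounds shown here, three sharing one core have been tested in a functional assay on THP-1 cells (Homo sapiens) for cytotoxicity, read by MTT assay, with a stated time of 24 h; on this read-out higher numbers stand for weaker inhibition and lower numbers for stronger inhibition. Compound 1 `COc1ccc(/C=C2\CC[C@H]3C(C)(C)CCC[C@]3(C)[C@H]2CCC(C)CC(=O)O)cc1` gives only a limit of the assay, > 200000 nM. Compound 2 `CC(CC[C@H]1/C(=C/c2ccc([N+](=O)[O-])cc2)CC[C@H]2C(C)(C)CCC[C@]12C)CC(=O)O` gives 180000 nM. Compound 3 `CC(CC[C@H]1/C(=C/c2ccc(Cl)cc2)CC[C@H]2C(C)(C)CCC[C@]12C)CC(=O)O` again gives only a limit, > 200000 nM. So compound 3 stands at a limit, not at a number, and the same holds for one further value in the set, as the limit of > 200000 nM in this assay, at which 2 of the 3 values shown sit, shows.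

Compound 4 `CC(CC[C@H]1/C(=C/c2ccc(I)cc2)CC[C@H]2C(C)(C)CCC[C@]12C)CC(=O)O` differs from compound 3 by iodo in place of chloro on an aromatic carbon. Within the data shown here, none of the measured steps swaps one halogen for another, and all are small or unreadable: an at least 1.1-fold lower number from compound 1 to compound 2 (0.04 log units; that floor lies within the scatter), a step that the two limits leave unreadable from compound 1 to compound 3, and an at least 1.1-fold higher number from compound 2 to compound 3 (0.04 log units; that floor lies within the scatter). Nothing here points to a change beyond the scatter in this assay when chloro gives way to iodo.

Compound 4 is therefore expected to give about 200000 nM, within a range from 90000 nM to 450000 nM. The step this estimate implies, a number no higher from compound 3 to compound 4 (the limit leaves the size open), is expected to stay within the scatter, and a further limit rather than a number is the likely outcome.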

Compound 4, half-maximal inhibitory concentration: 68000 nM
Estimate against measurement, compound 4: 2.9-fold (0.47 log units) above; measured number outside the range, below it.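

Among these compounds, on this aromatic carbon, para to a large group, the two halogens are not interchangeable in this assay: iodo in place of chloro gives a step beyond the scatter, which none of the earlier steps was (an at least 2.9-fold lower number from compound 3 to compound 4 (0.46 log units; beyond the scatter)). Compound 4 also separates from the nitro compound (a 2.6-fold lower number from compound 2 to compound 4 (0.42 log units; beyond the scatter)) and from the methoxy compound (an at least 2.9-fold lower number from compound 1 to compound 4 (0.46 log units; beyond the scatter)), which makes it the strongest of the four, though still weak in absolute terms. Two of these three steps are only floors, because compound 1 and compound 3 sit at a limit: the limit of > 200000 nM in this assay, at which 2 of the 4 values shown sit.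

With only chloro and iodo shown, it remains open whether bromo or fluoro at this place would fall in line with either. An amine here, or iodo on another carbon of the ring, would show how specific the gain is, and the values shown do not say why iodo differs.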